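Methylating the phenol of a weak A549 urea

The source may report more compounds than this note shows. Statements on the series, on what has been measured and on what is new or still open speak of the compounds shown alone.

Compound 1 `O=C(Nc1cccc(-n2cc(-c3ccncc3)c(-c3cc(O)cc(Cl)c3)n2)c1)Nc1ccc(Cl)c(C(F)(F)F)c1`: 81%
Compound 2 `O=C(Nc1cccc(-n2cc(-c3ccncc3)c(-c3cc(O)cc(Cl)c3)n2)c1)Nc1ccc(Cl)c(Cl)c1`: 75%

Two ureas share a core and differ on the outer aryl ring. In a functional assay on A549 cells (Homo sapiens) for inhibition, read by sulforhodamine B assay, with a stated time of 48 h, tested at 1 uM (a higher number here means a weaker effect of the compound at the concentration tested, a lower number a stronger effect), compound 1 gives 81%, and compound 2 gives 75%. Compound 1 holds the highest of the two numbers; its nearest neighbour is compound 2, with a number 6 percentage points lower from compound 1 to compound 2 (within the scatter), so the pair cannot be ordered.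

Compound 3 `COc1cc(Cl)cc(-c2nn(-c3cccc(NC(=O)Nc4ccc(Cl)c(C(F)(F)F)c4)c3)cc2-c2ccncc2)c1` is not yet measured. It differs from compound 1 by methyl in place of hydrogen on an oxygen on an aromatic ring, that is, hydroxy to methoxy on the 3-chloro-5-hydroxyphenyl ring. Among the measured compounds shown here, no measured step touches this position, so nothing in the data sets a direction or size for it. For the measured compounds named here, the only available step, the swap on the other ring, stayed within the scatter.

Compound 3 is therefore expected to stay near compound 1, with a number 1 percentage points lower from compound 1 to compound 3 (within the scatter), and an estimate of 80% is given for compound 3 in this assay, within the range 60% to 100%.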

Compound 3, a percentage reported as activity, at one concentration (the size of the read-out at that concentration, not a potency): 40%
Compound 3: middle estimate off by 40 percentage points, on the high side, outside the stated range (below it).
By their numbers in this assay, from the lowest: compound 3; then compounds 2 and 1 (each within the scatter of the next).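

The hydroxy group on the 3-chloro-5-hydroxyphenyl ring proves to be a sensitive place in this assay: changing it to methoxy gives a number 41 percentage points lower from compound 1 to compound 3 (beyond the scatter), so adding one methyl on this oxygen yields a clearly stronger effect at the concentration tested. The earlier change on the other aryl ring, a number 6 percentage points lower from compound 1 to compound 2 (within the scatter), gave no sign of such sensitivity on the shared core. No measurement is available that accounts for this gain.

The compounds shown leave open whether the gain depends on losing the hydroxy hydrogen or on gaining the methyl carbon, and whether an ethoxy group, a longer chain on this oxygen, or an amine in place of the hydroxy would keep it. They also leave open whether the same change would have a similar effect on compound 2.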